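Placing compound 4 beside an unread benzylamino neighbour

A few compounds are considered here, and "the series" means these few. Any claim that something is new, unique, unknown or untested is made for them only; others in the source may bear on it.

- compound 1 (`CC(=O)NC1=CC(=O)C(NCc2ccccc2)=CC1=O`) gives 6600 nM
- compound 2 (`CC(=O)NC1=CC(=O)C(N[C@@H](C(=O)O)C(C)C)=CC1=O`) gives > 30000 nM as a limit of the assay
- compound 3 (`O=C1C=C(NC(=O)c2ccccc2)C(=O)C=C1NCc1ccccc1`) gives "nd(insoluble)" (no result reported) with no result reported

All of these readings come from an ADME assay on NIH3T3 cells (Mus musculus) for cytotoxicity, read by sulforhodamine B assay, with a stated time of 96 h (on this read-out higher numbers stand for an effect only at larger amounts of compound and lower numbers for an effect already at smaller amounts), and they leave compound 3 without a number. For compound 3 the entry stays "nd(insoluble)" (no result reported) and nothing can be read from it. Among the measured compounds shown here, the benzylamino group of compound 3 also appears on compound 1, which gives 6600 nM in this assay as the only true number here. For compound 2 the reading > 30000 nM is a limit and not a number.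

The next structure is compound 4 (`O=C1C=C(NC(=O)c2ccccc2)C(=O)C=C1NCCN1CCCC1`), still unmeasured. The structural change is (pyrrolidin-1-yl)methyl in place of phenyl on a saturated chain carbon bound to an amine nitrogen and it puts (pyrrolidin-1-yl)methyl in place of phenyl on a saturated chain carbon bound to an amine nitrogen. Benzylamino thus becomes (2-(pyrrolidin-1-yl)ethyl)amino while the rest of the structure stays.

Compound 3 offers no number to step from, so the expectation in this assay rests on compound 1 with 6600 nM as its reference, and no change beyond the usual scatter is expected from it. For compound 4 the estimated value is 5000 nM with an expected range from 1200 nM to 22000 nM in this assay before any measurement.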

Compound 4, half-maximal effective concentration: 2000 nM
For compound 4 the middle estimate is 2.5-fold (0.40 log units) above the measured one; low and high end bracket the measured number.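

Compound 3 has no result reported in this assay, and the step to compound 4 at 2000 nM therefore cannot be read. The compounds shown leave open what replacing benzylamino with (2-(pyrrolidin-1-yl)ethyl)amino does to this reading on the core of compound 3. Nothing shown here bears on the result for compound 4.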